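Aryl Swaps at the Ring Nitrogen Leave Cytotoxicity Flat

The source may hold more compounds than are shown below. What is called first, only, known or untested is meant among the compounds shown, and "the series" means these compounds.

Three compounds have been measured in a functional assay on PC-12 cells (Rattus norvegicus) for cytotoxicity, read by MTT assay, with stated times of 2 h and 24 h, tested at 1 uM; a higher number here means a stronger effect of the compound at the concentration tested, a lower number a weaker effect:
compound 1 `CC(C)c1ccc(-n2nc(-c3ccc(C(F)(F)F)cc3O)nc2-c2ccccc2O)cc1` gives 69.7%
compound 2 `Oc1cc(C(F)(F)F)ccc1-c1nc(-c2ccccc2O)n(-c2ccccc2Cl)n1` gives 70.1%
compound 3 `COc1ccccc1-n1nc(-c2ccc(C(F)(F)F)cc2O)nc1-c1ccccc1O` gives 70.7%

Compound 3 holds the highest of the three numbers, but every step towards it stays inside the scatter: the nearest is the step of a number 0.6 percentage points higher from compound 2 to compound 3 (within the scatter), the furthest the step of a number 1 percentage points higher from compound 1 to compound 3 (within the scatter). The three compounds share a core and differ only in the aryl group on the aromatic nitrogen, and those differences have not moved the read-out.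

Compound 4 `Cc1cc(C)cc(-n2nc(-c3ccc(C(F)(F)F)cc3O)nc2-c2ccccc2O)c1` is not yet measured. It differs from compound 3 in one place: 3,5-dimethylphenyl in place of 2-methoxyphenyl on an aromatic nitrogen. For the measured compounds named here, the steps that bear on this change are the aryl swaps already seen at the same nitrogen, namely a number 0.4 percentage points higher from compound 1 to compound 2 (within the scatter) and a number 1 percentage points higher from compound 1 to compound 3 (within the scatter), together with the smaller change a number 0.6 percentage points higher from compound 2 to compound 3 (within the scatter); none left the scatter. The shift in compound 4 is therefore expected to be of the same kind, and the step of a number 0.7 percentage points lower from compound 3 to compound 4 (within the scatter) is estimated to fall within the scatter in either direction. For compound 4 the expected value in this assay is 70%, with a range from 62% to 78%.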

Compound 4, a percentage reported as activity, at one concentration (the size of the read-out at that concentration, not a potency): 76.9%
Compound 4: middle estimate off by 6.9 percentage points, on the low side, and the stated range covers the measured number.
By their numbers in this assay, from the lowest: compounds 1, 2, 3 and 4 (each within the scatter of the next).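

In this assay, the 3,5-dimethylphenyl group on the aromatic nitrogen gives steps of a larger size than any seen among the three earlier aryl groups, yet the step of a number 6.2 percentage points higher from compound 3 to compound 4 (within the scatter), the step of a number 6.8 percentage points higher from compound 2 to compound 4 (within the scatter) and the step of a number 7.2 percentage points higher from compound 1 to compound 4 (within the scatter) all remain inside the scatter, so no aryl group at this position has yet separated from the others. The swap from 2-methoxyphenyl to 3,5-dimethylphenyl also replaces a group that has a hydrogen-bond acceptor with one that has none, at an equal count of heavy atoms, and even this change does not take the read-out beyond the scatter. No independent measurement is available to account for the size of these steps.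

The compounds shown leave open whether a different kind of group on this nitrogen, such as an aminophenyl or carboxyphenyl ring, or a longer alkyl chain in place of the aryl ring, would produce a step beyond the scatter. They also leave open how the read-out responds to changes elsewhere on the shared core, since the trifluoromethyl and both hydroxyl groups stay the same throughout.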